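Phenyl in place of thiophen-3-yl on a shared core

The source may hold more compounds than are shown below. What is called first, only, known or untested is meant among the compounds shown, and "the series" means these compounds.

Values in an ADME assay on BJ cells (Homo sapiens), read by MTT assay, with a stated time of 72 h (on this read-out lower numbers stand for stronger inhibition and higher numbers for weaker inhibition), so far:
- compound 1 `CSc1ncnc2c1c(-c1ccoc1)cn2[C@@H]1O[C@H](CO)[C@@H](O)[C@H]1O` gives 98800 nM
- compound 2 `CSc1ncnc2c1c(-c1ccsc1)cn2[C@@H]1O[C@H](CO)[C@@H](O)[C@H]1O` gives 95800 nM

On these numbers, compound 2 shares its place with compound 1, the two lying within the scatter of each other. Compound 3 `CSc1ncnc2c1c(-c1ccccc1)cn2[C@@H]1O[C@H](CO)[C@@H](O)[C@H]1O` is reached by phenyl in place of thiophen-3-yl on an aromatic carbon, with phenyl in place of thiophen-3-yl on an aromatic carbon. Among the measured compounds shown here, the only measured step that bears on this is a 1.0-fold lower number from compound 1 to compound 2 (0.01 log units; within the scatter), and it stayed within the scatter. For the measured compounds named here, no compound carrying phenyl has been measured, so the evidence is thin. No change beyond the scatter is therefore expected in this assay. The expected step is a 1.1-fold lower number from compound 2 to compound 3 (0.03 log units; within the scatter). For compound 3 the estimated value is 90000 nM, with an expected range from 40000 nM to 150000 nM.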

Compound 3, half-maximal inhibitory concentration: > 100000 nM
Compound 3 gave a limit, no number (the forecaster's own chance of this, stated with the estimate: 30%); middle value at least 1.1-fold (0.04 log units) from the limit.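

In this assay compound 3 gives > 100000 nM, which is a limit of the assay and not a number. Phenyl at this aromatic carbon therefore shows no stronger inhibition than thiophen-3-yl or furan-3-yl, with steps of an at least 1.0-fold higher number from compound 2 to compound 3 (0.01 log units; that floor lies within the scatter) and an at least 1.0-fold higher number from compound 1 to compound 3 (0.00 log units; that floor lies within the scatter). How far compound 3 lies from the other two stays unsettled because of that limit: the limit of > 100000 nM in this assay, at which 1 of the 3 values shown sits.

Open is whether an amine or a carboxylic acid at this aromatic carbon, in place of the aromatic rings shown, would give a clearly lower number in this assay.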